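Ester substituent swap in a dihydropyrimidinone series at adenosine A2b

The source may hold more compounds than are shown below. What is called first, only, known or untested is meant among the compounds shown, and "the series" means these compounds.

Of the compounds shown here, two on the shared core have been measured in an assay on membranes from HEK293 cells for displacement of a labelled ligand from adenosine receptor A2b (Homo sapiens), read by scintillation counting, with a stated time of 30 min, tested at 1 uM; a lower number here means less inhibition, a higher number more inhibition at the concentration tested (going by the name of the read-out). Compound 1 `CC1=C(C(=O)OCc2ccccc2)C(c2ccsc2)NC(=O)N1` gives 44% in this assay, the higher of the two numbers. Among the compounds with values here, compound 2 `CCCOC(=O)C1=C(C)N(C)C(=O)NC1c1ccoc1` gives 2% in this assay, a number that stands well below that of compound 1; the two structures differ in several places, so their values show only that the number of compound 1 is the higher of the pair.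

Compound 3 `CC1=C(C(=O)OC2CCCCC2)C(c2ccsc2)NC(=O)N1` is not yet measured. It differs from compound 1 by cyclohexyl in place of benzyl on an oxygen next to a carbonyl group. Within the data shown here, with no single-change step available among the measured compounds, the size of this step can only be estimated. Compound 3 is expected to lose a modest amount relative to compound 1, a step of a number 9 percentage points lower from compound 1 to compound 3 (within the scatter), that may or may not exceed the scatter. Compound 3 is therefore estimated at 35% in this assay, in a range from 10% to 60%.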

Compound 3, a percentage reported as inhibition, at one concentration (the size of the read-out at that concentration, not a potency): 4%
Compound 3: middle estimate off by 31 percentage points, on the high side; the whole stated range lies above it.
By their numbers in this assay, from the lowest: compounds 2 and 3 (each within the scatter of the next); then compound 1.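

Within the data shown here, the change of benzyl to cyclohexyl on an oxygen next to a carbonyl group is the first single-change step, and in this assay it reads a number 40 percentage points lower from compound 1 to compound 3 (beyond the scatter) with the rest of the structure unchanged. This position is therefore sensitive to the group it carries, even though the exchange here replaces one six-membered ring of carbon only with another, aromatic for non-aromatic. No measurement at hand bears on the origin of this step.

Whether the aromatic ring alone accounts for the higher number of compound 1 stays open; a phenyl or phenethyl group on the same oxygen would test this. Compound 2 differs from the others in several places, so its steps cannot be read.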